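From bromo to iodo on the shared core

This account rests on a few compounds, and the source may have more. Where it says the series, first, only, none or still open, it means among the compounds named here.

- Compound 1 `C#C[C@@]1(O)[C@@H](CO)O[C@@H](n2cc(F)c3c(N)ncnc32)[C@@H]1O`: 67 nM
- Compound 2 `C#C[C@@]1(O)[C@@H](CO)O[C@@H](n2cc(Br)c3c(N)ncnc32)[C@@H]1O`: 18 nM

In an ADME assay on HUVEC cells (Homo sapiens) for antiproliferative activity, read by cell counting, with a stated time of 4 days (on this read-out lower numbers stand for stronger inhibition and higher numbers for weaker inhibition), compound 2 has the lower of the two numbers, at 18 nM. Compound 3 `C#C[C@@]1(O)[C@@H](CO)O[C@@H](n2cc(I)c3c(N)ncnc32)[C@@H]1O` comes next: iodo in place of bromo on an aromatic carbon. For the measured compounds named here, one measured step bears on this, the swap of bromo for fluoro at the same carbon: a 3.7-fold lower number from compound 1 to compound 2 (0.57 log units; beyond the scatter). It is modest but beyond the scatter. One step sets no firm trend, so a smaller change in the same direction is expected, perhaps none beyond the scatter. The estimated step is a 1.3-fold lower number from compound 2 to compound 3 (0.11 log units; within the scatter). Compound 3 is expected at 14 nM, with an estimated range of 5 nM to 40 nM.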

Compound 3, half-maximal inhibitory concentration: 9.9 nM
Estimate against measurement, compound 3: 1.4-fold (0.15 log units) above; low and high end bracket the measured number.
By their numbers in this assay, from the lowest: compounds 3 and 2 (each within the scatter of the next); then compound 1.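

Iodo in place of bromo at this carbon gives a step within the scatter (a 1.8-fold lower number from compound 2 to compound 3 (0.26 log units; within the scatter)), so bromo and iodo cannot be told apart in this assay. Fluoro, by contrast, stands clearly apart from iodo as well as from bromo (a 6.8-fold lower number from compound 1 to compound 3 (0.83 log units; beyond the scatter)), so among these three halogens, only fluoro separates from the others. Nothing measured here gives a reason for these differences.

As far as these compounds go, it remains open whether a group other than a halogen, such as a nitrile or an amine, would keep the number this low at the same carbon.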